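The source may report more compounds than this note shows. Statements on the series, on what has been measured and on what is new or still open speak of the compounds shown alone.

Measured so far in a functional assay on MDA-MB-435 cells (Homo sapiens) for cytotoxicity, read by MTT assay, with a stated time of 72 h; on this read-out lower numbers stand for stronger inhibition and higher numbers for weaker inhibition:
- compound 1 `O=C(NCc1ccc(F)cc1)c1nc(Br)c2cccnc2c1NCc1ccccc1` gives > 20000 nM.
- compound 2 `CS(=O)(=O)Oc1c(C(=O)NCc2ccc(F)cc2)nc(Br)c2cccnc12` gives > 20000 nM.
- compound 3 `Nc1ccc(Nc2c(C(=O)NCc3ccc(F)cc3)nc(Br)c3cccnc23)cc1` gives 7000 nM.

For compound 1 the value is a limit of this assay, not a number. For compound 2 the value is likewise a limit. Compound 3 is the only one of the three with a read number, and it stands as the limit of > 20000 nM in this assay, at which 2 of the 3 values shown sit, for the other two. The step of an at least 2.8-fold lower number from compound 1 to compound 3 (0.45 log units; beyond the scatter) and the step of an at least 2.8-fold lower number from compound 2 to compound 3 (0.45 log units; beyond the scatter) are both at least modest, yet each is read against a limit, so their true size is open. The step that the two limits leave unreadable from compound 1 to compound 2 is unreadable.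

Compound 4 `C[C@@H](Nc1c(C(=O)NCc2ccc(F)cc2)nc(Br)c2cccnc12)c1ccccc1` is the next case. The change from compound 3: 1-phenylethyl in place of 4-aminophenyl on a nitrogen on an aromatic ring. The step that bears on it is the reverse direction of compound 1 to compound 3, where benzyl on that nitrogen sat at the limit and 4-aminophenyl gave a number; the 1-phenylethyl group of compound 4 resembles benzyl in carrying no donor or acceptor. Compound 4 is therefore expected to move back toward the limit, with an estimated step of a 2.9-fold higher number from compound 3 to compound 4 (0.46 log units; beyond the scatter). Compound 4 is estimated at 20000 nM (range 7000 nM to 60000 nM).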

Compound 4, half-maximal inhibitory concentration: > 20000 nM
Compound 4 gave a limit, no number; the forecaster's own chance of this, stated with the estimate: 60%; the middle value lies on the limit itself.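

In this assay the change gives an at least 2.8-fold higher number from compound 3 to compound 4 (0.45 log units; beyond the scatter), so 1-phenylethyl on this nitrogen groups with benzyl rather than with 4-aminophenyl. Compound 4 sits at a limit of the assay, not at a number: the limit of > 20000 nM in this assay, at which 3 of the 4 values shown sit. The steps from compound 1 and from compound 2 to compound 4 join limit to limit and cannot be read, so the added methyl on the saturated chain carbon leaves the series without a second read number.

The compounds shown leave open whether the read number of compound 3, 7000 nM, depends on the ring amine or on the aromatic ring sitting directly on this nitrogen, which a plain phenyl or a 4-hydroxyphenyl group would separate. On these data alone, the mirror-image form of 1-phenylethyl also remains open.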